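Trifluoromethyl for Methoxy on the Chain-End Phenyl

The source may hold more compounds than are shown below. What is called first, only, known or untested is meant among the compounds shown, and "the series" means these compounds.

Compound 1 `COc1ccccc1/C=C/C(=O)OC/C=C/c1cc(OC)c(OC)cc1OC` was examined in a functional assay on the whole organism (strain Kunming) with Mus musculus as the target, with a stated time of 0.5 h, at a dose of 300 mg/kg by the intraperitoneal route (a higher number here means a weaker effect of the compound at the dose given, a lower number a stronger effect), and in that measurement compound 1 gives 100%. Two companions reached the same reading: compound 2 `COc1cc(OC)c(OC)cc1/C=C/COC(=O)/C=C/c1c(OC)ccc(OC)c1OC` gives 100% in this assay, and compound 3 `COc1cc(OC)c(OC)cc1/C=C/COC(=O)/C=C/c1ccc(Br)cc1` gives 100%. Compound 1 thus stands level with compounds 2 and 3 at the digits reported, its nearest neighbour being compound 2 and its furthest compound 3, neither separated from it by more than the scatter.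

One measured step speaks to the change now considered. The step of no change at the digits printed from compound 1 to compound 3 (within the scatter) replaced 4-bromophenyl for 2-methoxyphenyl on a double-bonded chain carbon bound to a double-bonded chain carbon, an exchange of the whole ring substituent, and the read-out did not move.

Compound 4 `COc1cc(OC)c(OC)cc1/C=C/COC(=O)/C=C/c1ccccc1C(F)(F)F` is the unmeasured member. Within the data shown here, its single difference from compound 1 is trifluoromethyl in place of methoxy on an aromatic carbon. The new group sits on an aromatic carbon of a six-membered aromatic ring of carbon only, ortho to a large group.

Because no change at the digits printed from compound 1 to compound 3 (within the scatter) showed no movement for a larger exchange at the same chain end, the smaller exchange in compound 4 is expected to show none either: an expected step of no change at the digits printed from compound 1 to compound 4 (within the scatter). The estimate for compound 4 in this assay is therefore 100%, expected to lie between 85% and 100%.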

Compound 4, a percentage reported as activity, at one dose (the size of the read-out at that dose, not a potency): 100%
Estimate against measurement, compound 4: no gap at the digits printed; measured number inside the range.
By their numbers in this assay, from the lowest: compounds 1, 2, 3 and 4 (each within the scatter of the next).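

In this assay, putting trifluoromethyl in place of methoxy on an aromatic carbon, ortho to a large group, gives no change at the digits printed from compound 1 to compound 4 (within the scatter): unlike the earlier step, which exchanged the whole ring substituent, this one alters a single group on the ring and still leaves the reading where it stood. The further step, no change at the digits printed from compound 3 to compound 4 (within the scatter), with 2-(trifluoromethyl)phenyl in place of 4-bromophenyl, means that the ring substituents of compound 1, compound 3 and compound 4 (2-methoxyphenyl, 4-bromophenyl and 2-(trifluoromethyl)phenyl) are not told apart by this read-out. Nothing available accounts for this outcome.

The compounds shown leave open whether an amine or a carboxylic acid on this ring, or a longer chain linking the ring to the ester carbonyl, would shift the reading from the level shared here. On these data alone, with all four compounds reading alike, it also remains open which part of the structure, if any, this read-out depends on.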